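Dropping the fluorine from a bibenzyl antiproliferative

The compounds below may be only part of what the source reports. "The series", "measured", "known", "first", "only" and "open" are said of these compounds alone.

Measured compounds:
compound 1 `COc1cc(CCc2ccc(F)cc2)cc(OC)c1O`: 4150 nM
compound 2 `COc1ccc(CCc2ccccc2Cl)cc1OC`: > 25000 nM

Of the compounds shown here, two of a shared bibenzyl type have been measured in a functional assay on A549 cells (Homo sapiens) for antiproliferative activity, read by MTT assay, with a stated time of 72 h; a higher number here means a weaker inhibitor, a lower number a stronger inhibitor. Within the data shown here, compound 1 `COc1cc(CCc2ccc(F)cc2)cc(OC)c1O` gives 4150 nM, and it is the only compound here with a numeric result. Compound 2 `COc1ccc(CCc2ccccc2Cl)cc1OC` reaches only the limit of the assay, > 25000 nM, so no number is known for it. Compound 1 therefore stands as the single reference point, while the other value is a limit, (the limit of > 25000 nM in this assay, at which 1 of the 2 values shown sits).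

Compound 3 `COc1cc(CCc2ccccc2)cc(OC)c1O` is the next compound to be measured. It differs from compound 1 in one place: hydrogen in place of fluoro on an aromatic carbon. Among the measured compounds shown here, no measured pair shows what this exchange does here, so the expectation rests on the change itself, which removes one small atom and adds nothing else.

The step is expected to be small, not beyond the usual scatter, and its size is estimated as a 1.2-fold higher number from compound 1 to compound 3 (0.08 log units; within the scatter). In this assay compound 3 is expected to give about 5000 nM. For compound 3 the estimated range runs from 2000 nM to 12000 nM.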

Compound 3, half-maximal inhibitory concentration: 10900 nM
For compound 3 the middle estimate is 2.2-fold (0.34 log units) below the measured one; measured number inside the range.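

In this assay, hydrogen in place of fluoro on an aromatic carbon, para to a large group, gives a 2.6-fold higher number from compound 1 to compound 3 (0.42 log units; beyond the scatter). Among these compounds, this is the first measured pair that differs in one place, and it shows that this position is sensitive: losing a single fluorine atom leaves a modest but real weakening, with compound 1 the stronger inhibitor of the two. The data shown do not explain why this exchange has an effect of this size, so the result stands as an observation without a measured cause.

The pair compares only fluoro and hydrogen, so it cannot show whether fluoro is a particularly good choice here or whether chloro, methoxy, an amine or a carboxylic acid at the same position would give a stronger or weaker inhibitor. It also leaves open whether the same exchange would have a similar effect on a core with a different arrangement of groups on the other aromatic ring, since this single step comes from one pair in one cell line.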